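A few compounds are considered here, and "the series" means these few. Any claim that something is new, unique, unknown or untested is made for them only; others in the source may bear on it.

Measured so far:
- compound 1, `C=CCOC(=O)Nc1ccc([Se]C#N)cc1`: 72800 nM
- compound 2, `O=C(Nc1ccc([Se][Se]c2ccc(NC(=O)OCc3ccccc3)cc2)cc1)OCc1ccccc1`: 69000 nM

In a functional assay on HT-29 cells (Homo sapiens) for cytotoxicity, read by MTT assay, with a stated time of 72 h (a higher number here means that more compound is tolerated, a lower number that less compound is tolerated), compound 1 gives 72800 nM and compound 2 gives 69000 nM; the two values lie within the scatter of each other, so neither is told apart from the other on these numbers. Among the measured compounds shown here, no step between measured compounds is recorded for this assay.

Compound 3, `CCCCOC(=O)Nc1ccc([Se]C#N)cc1`, is not yet measured. It shares the core of compound 1 and differs from it in one place: propyl in place of vinyl on a saturated chain carbon bound to an oxygen next to a carbonyl group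

For the measured compounds named here, with only two values in hand, both within the scatter of each other, there is no measured step that speaks to this change. The expectation is no step beyond the scatter, in either direction. For compound 3 the expected value in this assay is 70000 nM, with a range from 30000 nM to 160000 nM, which amounts to an expected step of a 1.0-fold lower number from compound 1 to compound 3 (0.02 log units; within the scatter).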

Compound 3, concentration lethal to 50% of the cells: 63700 nM
Estimate against measurement, compound 3: 1.1-fold (0.04 log units) above; the range from low to high includes it.
By their numbers in this assay, from the lowest: compounds 3, 2 and 1 (each within the scatter of the next).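

In this assay, among the compounds shown here, the exchange of vinyl for propyl on a saturated chain carbon bound to an oxygen next to a carbonyl group gives a 1.1-fold lower number from compound 1 to compound 3 (0.06 log units; within the scatter) and is the first measured step at this position. In this pair, allyl and butyl are not told apart, so the double bond outside aromatic rings in compound 1 is not needed to keep the value in the range of compound 3. No measurement at hand offers an explanation for this result.

A single step within the scatter sets no trend with chain length at this position. As far as these compounds go, whether a longer chain, an amine or a carboxylic acid at the same place would give a step beyond the scatter remains open.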